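A few compounds are considered here, and "the series" means these few. Any claim that something is new, unique, unknown or untested is made for them only; others in the source may bear on it.

Compound 1 `CC(C)(C)Nc1nccc2c(-c3ccnc(NC4CCCC4)n3)c(-c3ccc(F)cc3)nn12`: > 40000 nM
Compound 2 `COc1ccc(-c2nn3c(NC4CCCC4)ccnc3c2-c2ccnc(NC3CCCC3)c2)cc1`: 10000 nM

Of the compounds shown here, two have been tested in an ADME assay on Vero cells (Chlorocebus sabaeus) for cytotoxicity; a higher number here means that more compound is tolerated, a lower number that less compound is tolerated. Compound 1 gives > 40000 nM, which is a limit of the assay and not a measured number; it is the limit of > 40000 nM in this assay, at which 1 of the 2 values shown sits. Among the measured compounds shown here, compound 2 gives 10000 nM in this assay, and this is the only true number among the values shown. Compound 3 `Fc1ccc(-c2nn3c(NC4CCCC4)ccnc3c2-c2ccnc(NC3CCCC3)c2)cc1` has not yet been tested. It differs from compound 2 in a single place: fluoro in place of methoxy on an aromatic carbon. For the measured compounds named here, no pair of already measured compounds shows what such a change does here, so there is no measured step to lean on. The step expected from this change, no change at the digits printed from compound 2 to compound 3 (within the scatter), is small, no larger than the usual scatter in either direction. Compound 3 is therefore estimated to give about 10000 nM in this assay, with a likely range from 4000 nM to 30000 nM.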

Compound 3, half-maximal cytotoxic concentration: 16000 nM
Compound 3: middle estimate off by 1.6-fold (0.20 log units), on the low side; measured number inside the range.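

Among the compounds shown here, changing 4-methoxyphenyl to 4-fluorophenyl gives the first readable step at this place on the shared core: in this assay, the change produces a 1.6-fold higher number from compound 2 to compound 3 (0.20 log units; within the scatter), so the two compounds cannot be ranked. For this pair, then, replacing methoxy with fluoro leaves the tolerated concentration indistinguishable from repeated measurements of one compound. Compound 1 differs from both in more than one place and offers no third point for this comparison, and its value is a limit: the limit of > 40000 nM in this assay, at which 1 of the 3 values shown sits.

One pair cannot show whether the same swap would behave alike on a different core. It also leaves open what an amine, a carboxylic acid or a longer chain at this place on the aromatic ring would do to the number.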